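The source may report more compounds than this note shows. Statements on the series, on what has been measured and on what is new or still open speak of the compounds shown alone.

Measured compounds:
compound 1, `Cn1c(-c2ccc(NC(=O)CSc3nc4ccccc4o3)cc2)nc(-c2ccccc2)c1-c1ccccc1`, 11 ug/mL in a functional assay on HT-29 cells (Homo sapiens) for cytotoxicity, read by MTT assay, with a stated time of 24 h; on this read-out lower numbers stand for stronger inhibition and higher numbers for weaker inhibition
compound 2, `Cn1c(-c2ccc(NC(=O)CSc3nc4cc(Cl)ccc4o3)cc2)nc(-c2ccccc2)c1-c1ccccc1`, 20.6 ug/mL in this assay
compound 3, `Cn1nnnc1SCC(=O)Nc1ccc(-c2nc(-c3ccccc3)c(-c3ccccc3)n2C)cc1`, 1.6 ug/mL in this assay

Compound 3 gives the lowest number of the three in this assay. Its nearest neighbour is compound 1, with a 6.9-fold lower number from compound 1 to compound 3 (0.84 log units; beyond the scatter), and its furthest is compound 2, with a 13-fold lower number from compound 2 to compound 3 (1.11 log units; beyond the scatter); the two benzoxazole compounds sit close together, a 1.9-fold higher number from compound 1 to compound 2 (0.27 log units; within the scatter). The unmeasured compound 4, `CCN1CCN(CC(=O)Nc2ccc(-c3nc(-c4ccccc4)c(-c4ccccc4)n3C)cc2)CC1`, differs from compound 3 in one place: 4-ethylpiperazin-1-yl in place of (1-methyl-1H-tetrazol-5-yl)sulfanyl on a saturated chain carbon bound to a carbonyl carbon. Going by the values given here, no measured step replaces the sulfur-linked group by an amine, so the only guide is that changing the group on the sulfur moved the number beyond the scatter twice, and that the heteroaryl of compound 3 gave the lowest value. A larger change of this kind is expected to move the number again, more likely upward than downward, so compound 4 is expected to give 5 ug/mL, within 1.5 ug/mL to 20 ug/mL, an expected step of a 3.1-fold higher number from compound 3 to compound 4 (0.49 log units; beyond the scatter).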

Compound 4, half-maximal inhibitory concentration: 75 ug/mL
For compound 4 the middle estimate is 15-fold (1.18 log units) below the measured one; measured number outside the range, above it.
By their numbers in this assay, from the lowest: compound 3; then compounds 1 and 2 (each within the scatter of the next); then compound 4.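

In this assay, going by these compounds alone, the earlier steps changed only the aromatic ring on the sulfur, whereas replacing the whole sulfur-linked group with 4-ethylpiperazin-1-yl on a saturated chain carbon bound to a carbonyl carbon gives a 47-fold higher number from compound 3 to compound 4 (1.67 log units; beyond the scatter), the largest step. The change also raises the number from both benzoxazole compounds, with a 6.8-fold higher number from compound 1 to compound 4 (0.83 log units; beyond the scatter) and a 3.6-fold higher number from compound 2 to compound 4 (0.56 log units; beyond the scatter), so 4-ethylpiperazin-1-yl gives a higher number than each of the three sulfur-linked groups shown. No measurement available here bears on why the number rises at this position.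

The compounds shown leave open whether the sulfur, the aromatic ring on it, or the 4-ethylpiperazin-1-yl ring itself accounts for the rise. A methylsulfanyl group, a morpholine or a 1-methyl-1H-tetrazol-5-yl group joined through an amine nitrogen at this place would help separate these possibilities.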